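The compounds below may be only part of what the source reports. "The series", "measured", "known", "first", "only" and "open" are said of these compounds alone.

Compound 3 `CC(C)c1c(C(=O)NCc2ccccn2)nn(-c2ccc(F)cc2)c1OC[C@@H](O)C[C@@H](O)CC(=O)O` has in a functional assay on L6 cells (Rattus norvegicus) for inhibition (on this read-out lower numbers stand for stronger inhibition and higher numbers for weaker inhibition), only the entry "not determined" (no result reported): no number was obtained for it, so it cannot be placed against the other compounds. Two members of the same series do carry numbers. Within the data shown here, compound 1 `CC(C)c1c(C(=O)N(C)Cc2ccccc2)nn(-c2ccc(F)cc2)c1OC[C@@H](O)C[C@@H](O)CC(=O)O` gives 6720 nM in this assay, and compound 2 `CC(C)c1c(C(=O)N2CCC[C@H](c3ccccc3)C2)nn(-c2ccc(F)cc2)c1OC[C@@H](O)C[C@@H](O)CC(=O)O` gives 1110 nM in this assay; the one recorded step, a 6.1-fold lower number from compound 1 to compound 2 (0.78 log units; beyond the scatter), shows that exchanging the group on the carbonyl carbon moves the read-out beyond the scatter, with 3-phenylpiperidin-1-yl in place of benzyl(methyl)amino. Compound 4 `CC(C)c1c(C(=O)N(C)Cc2cccc(F)c2)nn(-c2ccc(F)cc2)c1OC[C@@H](O)C[C@@H](O)CC(=O)O` differs from compound 3 at that same carbonyl carbon: (3-fluorobenzyl)(methyl)amino in place of ((pyridin-2-yl)methyl)amino on a carbonyl carbon. The group that enters, (3-fluorobenzyl)(methyl)amino, closely resembles the benzyl(methyl)amino of compound 1, so compound 1 is the nearest measured anchor; the step from compound 1 to compound 2 does not involve the group of compound 4 and gives only a sense of how far such exchanges can reach. With compound 3 unmeasured, no direction can be stated. Compound 4 is therefore expected to lie near compound 1, estimated at 5000 nM in this assay, with a range from 1500 nM to 16000 nM.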

Compound 4, half-maximal inhibitory concentration: 2470 nM
The estimate for compound 4 lay 2.0-fold (0.31 log units) above the measured number; the measured number falls inside the stated range.
By their numbers in this assay, from the lowest: compound 2; then compound 4; then compound 1.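

Fluoro in place of hydrogen on an aromatic carbon gives, in this assay, a 2.7-fold lower number from compound 1 to compound 4 (0.43 log units; beyond the scatter) and so shows that this amide substituent responds to a single-atom change, whereas the earlier step exchanged the whole group. Even so, (3-fluorobenzyl)(methyl)amino in place of 3-phenylpiperidin-1-yl gives a 2.2-fold higher number from compound 2 to compound 4 (0.35 log units; beyond the scatter) and leaves compound 2 with the lowest number of the three. The step from compound 3 cannot be read, and no available evidence accounts for these shifts.

From the compounds shown here alone, whether chloro or methoxy in place of that fluoro would carry the number further down remains open. So does the standing of ((pyridin-2-yl)methyl)amino, and of a benzylamino group with the amide hydrogen kept, against the methylated benzyl amides.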